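Geometric isomer pair on the naphthyl-trimethoxyphenyl series

A few compounds are considered here, and "the series" means these few. Any claim that something is new, unique, unknown or untested is made for them only; others in the source may bear on it.

The series shares a trimethoxyphenyl group and a naphthyl group on one carbon. Compound 1 `COc1ccc(C(OCc2ccccc2)c2cccc3ccccc23)c(OC)c1OC` carries a benzyloxy group on that carbon and in a functional assay on MCF7 cells (Homo sapiens) for inhibition, read by sulforhodamine B assay, with a stated time of 48 h (a higher number here means a weaker inhibitor, a lower number a stronger inhibitor), compound 1 gives 14100 nM. Compound 2 `C=CCC(O)(c1ccc(OC)c(OC)c1OC)c1cccc2ccccc12` carries an allyl group and a hydroxyl; in this assay compound 2 gives only the limit > 20000 nM, a boundary of the measurement rather than a number. Compound 3 `COc1ccc(/C(=C\c2ccc(F)cc2)c2cccc3ccccc23)c(OC)c1OC` is the olefin with a fluorophenyl group drawn Z; in this assay compound 3 gives 17700 nM, the highest of the two numbers, with compound 1 close and within the scatter. Compound 2 stands apart at the boundary of the measurement (the limit of > 20000 nM in this assay, at which 1 of the 3 values shown sits).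

Compound 4 `COc1ccc(/C(=C/c2ccc(F)cc2)c2cccc3ccccc23)c(OC)c1OC` is the unmeasured counterpart: the two compounds have the same atoms and bonds and differ only in configuration as drawn: 1 of 1 stereo elements differ; a double bond is drawn Z in compound 3 and E in compound 4. Among the measured compounds shown here, no measured pair in this set differs only in double-bond geometry, so the size of this step is not established. With compound 3 at 17700 nM, a step from compound 3 to compound 4 of a 1.1-fold higher number from compound 3 to compound 4 (0.05 log units; within the scatter) is expected, no larger than the scatter. Compound 4 is estimated in this assay at 20000 nM, between 8000 nM and 50000 nM.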

Compound 4, half-maximal inhibitory concentration: 10500 nM
The estimate for compound 4 lay 1.9-fold (0.28 log units) above the measured number, and the stated range covers the measured number.
By their numbers in this assay, from the lowest: compounds 4, 1 and 3 (each within the scatter of the next). At a limit, above all of these: compound 2.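

The double bond now has a measured geometry pair: in this assay the step is a 1.7-fold lower number from compound 3 to compound 4 (0.23 log units; within the scatter). Among the compounds shown here, this step isolates the geometry of the double bond, with no other structural change involved: the fact that compounds 3 and 4 differ only in the configuration as drawn On these numbers, the drawn geometry does not separate the two olefins in this assay, which the earlier compounds could not show.

The compounds shown hold only this one geometry pair, with the fluorophenyl group in both members, so it remains open whether the step stays within the scatter with an amine or a carboxylic acid on that ring. Only one assay on one cell line is shown, so the size of this step in any other read-out also remains open.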